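Cytotoxicity notes: amine swap on the chain carbon

This account rests on a few compounds, and the source may have more. Where it says the series, first, only, none or still open, it means among the compounds named here.

Compound 3 `COc1ccc2[nH]c(C(=O)N3CC(=O)N(Cc4ccccc4)[C@@H](CN4CC5CC5C4)C3)cc2c1` gives 13800 nM in an ADME assay on Vero cells (Chlorocebus sabaeus) for cytotoxicity, with a stated time of 7 days (a lower number here means that less compound is tolerated, a higher number that more compound is tolerated), the second highest of the three numbers. Compound 1 `COc1ccc2[nH]c(C(=O)N3CC(=O)N(Cc4ccccc4)[C@@H](CN4CCC5(CC4)CC5)C3)cc2c1` gives 17100 nM, and a 1.2-fold lower number from compound 1 to compound 3 (0.09 log units; within the scatter) lies within the scatter. For the measured compounds named here, compound 2 `COc1ccc2[nH]c(C(=O)N3CC(=O)N(Cc4ccccc4)[C@@H](N4[C@H](C)CCC[C@@H]4C)C3)cc2c1` gives 1400 nM; a 12-fold lower number from compound 1 to compound 2 (1.09 log units; beyond the scatter) and a 9.9-fold higher number from compound 2 to compound 3 (0.99 log units; beyond the scatter) are the only steps beyond the scatter, and both involve the amine bound directly to the saturated ring carbon rather than to the chain carbon. Compound 4 `COc1ccc2[nH]c(C(=O)N3CC(=O)N(Cc4ccccc4)[C@@H](CN4CCc5ccccc5C4)C3)cc2c1` carries a group of 10 heavy atoms (9 carbon, 1 nitrogen; one six-membered non-aromatic ring with 1 hetero atom, one six-membered aromatic ring of carbon only) in place of a group of 6 heavy atoms (5 carbon, 1 nitrogen; one three-membered non-aromatic ring of carbon only, one five-membered non-aromatic ring with 1 hetero atom), on a saturated chain carbon bound to a saturated ring carbon. The step from compound 1 to compound 3, a swap of the amine on the same chain carbon, is the one that bears on this change, and it stayed within the scatter. No step beyond the scatter is therefore expected in this assay. Compound 4 is estimated at 12000 nM, with a range from 5000 nM to 30000 nM. The expected step is a 1.2-fold lower number from compound 3 to compound 4 (0.06 log units; within the scatter).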

Compound 4, half-maximal cytotoxic concentration: 51800 nM
The estimate for compound 4 lay 4.3-fold (0.64 log units) below the measured number, and the stated range ends below it.
By their numbers in this assay, from the lowest: compound 2; then compounds 3 and 1 (each within the scatter of the next); then compound 4.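

In this assay, for the compounds shown here, the amine on the saturated chain carbon does matter, with 1,2,3,4-tetrahydroisoquinolin-2-yl giving a 3.8-fold higher number from compound 3 to compound 4 (0.57 log units; beyond the scatter) and a 3.0-fold higher number from compound 1 to compound 4 (0.48 log units; beyond the scatter) as the only steps beyond the scatter among amines on that carbon. The widest gap in the set is a 37-fold higher number from compound 2 to compound 4 (1.57 log units; beyond the scatter) against 2,6-dimethylpiperidin-1-yl on the saturated ring carbon, a step that changes both the amine and its attachment. Nothing measured here accounts for the higher number.

From the compounds shown here alone, whether the aromatic ring is what counts stays open, and a piperidin-1-yl on the same chain carbon would test it. Also open, going by these compounds, is how a methoxy or a fluorine on that aromatic ring would read.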